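This account rests on a few compounds, and the source may have more. Where it says the series, first, only, none or still open, it means among the compounds named here.

Of the compounds shown here, three built on the same core have been measured in a physicochemical assay for acid dissociation. Compound 1 `c1ccc(Oc2ccc3c(NCCCNCc4ccco4)ccnc3c2)cc1` gives 9.28 in this assay. Compound 2 `COc1cccc(CNCCCNc2ccnc3cc(Oc4ccc(Cl)cc4)ccc23)c1O` gives 9.28 in this assay, and compound 3 `CC(C)CCc1ccc2c(NCCCNCc3ccco3)ccnc2c1` gives 9.47 in this assay. Compound 2 thus stands level with compound 1 at the digits shown, the two together forming the lowest pair of the three numbers, and compound 3 differs from compound 2 only within the scatter. Compound 4 `COc1cccc(CNCCCNc2ccnc3cc(Cc4ccccc4)ccc23)c1O` has not yet been measured; it differs from compound 2 in one place: benzyl in place of 4-chlorophenoxy on an aromatic carbon. Going by the values given here, the one measured step at a comparable place, a number 0.19 log units higher from compound 1 to compound 3 (within the scatter), stayed within the scatter, so swapping a group on that aromatic carbon has so far produced no step beyond the scatter in this assay. The change to compound 4 is therefore expected to bring no step beyond the scatter, an expected a number 0.02 log units higher from compound 2 to compound 4 (within the scatter). For compound 4 the estimate in this assay is 9.3, with a range from 9 to 9.6.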

Compound 4, acid dissociation constant: 9.47
For compound 4 the middle estimate is 0.17 log units below the measured one; the range from low to high includes it.
By their numbers in this assay, from the lowest: compounds 1, 2, 3 and 4 (each within the scatter of the next).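

In this assay, benzyl in place of 4-chlorophenoxy on this aromatic carbon gives a number 0.19 log units higher from compound 2 to compound 4 (within the scatter), so a second pair of compounds, differing from the first elsewhere in the structure, also shows no step beyond the scatter for a swap at this position. This swap removes the oxygen and the chlorine of the leaving group, along with its one hydrogen-bond acceptor, and still the read-out shows no step beyond the scatter. No independent evidence bears on this result.

From the compounds shown here alone, the groups compared on this carbon are phenoxy, 4-chlorophenoxy, isopentyl and benzyl, so it remains open whether an amine or a carboxylic acid there would also stay within the scatter. Equally open, going by these compounds, is whether a much smaller group, such as fluorine or a nitrile, would do the same.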